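Swapping a Six-Membered Amine Ring for a Five-Membered One

The source may report more compounds than this note shows. Statements on the series, on what has been measured and on what is new or still open speak of the compounds shown alone.

Of the compounds shown here, three in this set have been tested in a functional assay on NCI-H460 cells (Homo sapiens) for cytotoxicity, read by MTT assay, with a stated time of 72 h (a lower number here means a stronger inhibitor, a higher number a weaker inhibitor), and a fourth awaits its result. Compound 1 has the structure `COc1cccc(-c2cc(C(=O)Nc3ccc(Oc4ccnc5cc(OCCCN6CCCCC6)c(OC)cc45)c(F)c3)c3ccccc3n2)c1` and gives 210 nM in this assay. Compound 2, with the structure `COc1cccc(-c2cc(C(=O)Nc3ccc(Oc4ccnc5cc(OCCCN6CCCC6)c(OC)cc45)c(F)c3)c3ccccc3n2)c1`, differs from compound 1 in one place only: pyrrolidin-1-yl in place of piperidin-1-yl on a saturated chain carbon, three bonds along the chain from an oxygen on an aromatic ring. In this assay compound 2 gives 290 nM. That change produced a 1.4-fold higher number from compound 1 to compound 2 (0.14 log units; within the scatter), a step too small to count as a real change.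

Compound 3 has the structure `COc1cc2c(Oc3ccc(NC(=O)c4cc(-c5ccccc5)nc5ccc(F)cc45)cc3F)ccnc2cc1OCCCN1CCCCC1` and is built on a different core from compound 1; the difference between the two cores is not broken down here. In this assay compound 3 gives 32 nM, which stands furthest from compound 2 and nearest to compound 1, and beyond the scatter from both.

Compound 4, with the structure `COc1cc2c(Oc3ccc(NC(=O)c4cc(-c5ccccc5)nc5ccc(F)cc45)cc3F)ccnc2cc1OCCCN1CCCC1`, is not yet measured. It relates to compound 3 exactly as compound 2 relates to compound 1: pyrrolidin-1-yl in place of piperidin-1-yl on a saturated chain carbon, three bonds along the chain from an oxygen on an aromatic ring. The place of the change reads the same in both pairs, so this is the same change made on a different core.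

Because the earlier step gave a 1.4-fold higher number from compound 1 to compound 2 (0.14 log units; within the scatter), compound 4 is expected to sit close to compound 3, with an estimated step of a 1.4-fold higher number from compound 3 to compound 4 (0.15 log units; within the scatter). The estimate for compound 4 in this assay is 45 nM, expected to lie between 20 nM and 100 nM. This rests on a single earlier example, so the range is kept wide.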

Compound 4, half-maximal inhibitory concentration: 90 nM
The estimate for compound 4 lay 2.0-fold (0.30 log units) below the measured number, and the stated range covers the measured number.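

On the core of compound 3, putting pyrrolidin-1-yl in place of piperidin-1-yl gives a 2.8-fold higher number from compound 3 to compound 4 (0.45 log units; beyond the scatter) in this assay, a modest loss of strength that is large enough to count as real. Set beside the same change on the core of compound 1, the gap between the two steps is no larger than repeated measurements could produce, so these two cores cannot be told apart in how they respond to this swap: the same change on two cores in this assay, a 1.4-fold higher number (0.14 log units; within the scatter) from compound 1 to compound 2 and a 2.8-fold higher number (0.45 log units; beyond the scatter) from compound 3 to compound 4, 2.0-fold (0.31 log units) apart, within the scatter of two such steps This shows that the change carried over from one core to the other without any detectable difference in the size of its step, but with only two pairs it does not show that the step would stay the same on other cores in the series, and it gives no explanation for why one step lies beyond the scatter and the other within it.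

The compounds shown leave open how other amines at the end of the propyl chain, such as a morpholine ring or an open-chain dimethylamino group, would behave on either core. Also open, going by these compounds, is whether a shorter or longer chain carrying these same two rings would give steps of similar size.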